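The compounds below may be only part of what the source reports. "The series", "measured", "known", "first", "only" and "open" are said of these compounds alone.

In a functional assay on NCI-H460 cells (Homo sapiens) for antiproliferative activity, read by XTT assay, with a stated time of 72 h (a lower number here means a stronger inhibitor, a higher number a weaker inhibitor), compound 3 `COc1ccc(-c2cc3ccccc3nc2/C=C/C(=O)c2ccco2)cc1` gives 6430 nM, the lowest of the two numbers obtained so far. Its nearest neighbour is compound 2 `COc1ccc(-c2cc3ccccc3nc2/C=C/C(=O)c2ccc(N)cc2)cc1`, which gives 7400 nM. Compound 1 `COc1ccc(C(=O)/C=C/c2nc3ccccc3cc2-c2ccc(OC)cc2)cc1` yields only a limit of the assay, > 10000 nM (the limit of > 10000 nM in this assay, at which 1 of the 3 values shown sits). Compound 4 `COc1ccc(-c2cc3ccccc3nc2/C=C/C(=O)c2cccs2)cc1` differs from compound 3 by thiophen-2-yl in place of furan-2-yl on a carbonyl carbon. The steps that touch the same carbonyl carbon, an at least 1.5-fold lower number from compound 1 to compound 3 (0.19 log units; that floor lies within the scatter) and a 1.2-fold lower number from compound 2 to compound 3 (0.06 log units; within the scatter), were both small, and the remaining step of an at least 1.3-fold lower number from compound 1 to compound 2 (0.13 log units; that floor lies within the scatter) was small as well. One therefore expects a step of a 1.2-fold lower number from compound 3 to compound 4 (0.07 log units; within the scatter), nothing beyond the scatter in either direction. On that basis compound 4 is estimated at 5500 nM, with a likely range from 2500 nM to 12000 nM.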

Compound 4, half-maximal inhibitory concentration: 5440 nM
Compound 4: the middle estimate sits 1.0-fold (0.00 log units) above what was measured, within the range that was stated.
By their numbers in this assay, from the lowest: compounds 4, 3 and 2 (each within the scatter of the next). At a limit, above all of these: compound 1.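

In this assay, the step with thiophen-2-yl in place of furan-2-yl on the carbonyl carbon is a 1.2-fold lower number from compound 3 to compound 4 (0.07 log units; within the scatter), so exchanging the ring oxygen for sulfur does not move the number beyond the scatter. Thiophen-2-yl in place of 4-aminophenyl gives a 1.4-fold lower number from compound 2 to compound 4 (0.13 log units; within the scatter), which leaves compounds 2, 3 and 4 all within the scatter of one another. The remaining step, an at least 1.8-fold lower number from compound 1 to compound 4 (0.26 log units; that floor lies within the scatter), is only a floor, since compound 1 stands at a limit: the limit of > 10000 nM in this assay, at which 1 of the 4 values shown sits.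

As far as these compounds go, what an aliphatic amine, a carboxylic acid or a longer alkyl chain on this carbonyl carbon would give stays open.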